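A Methoxy Group Added to Compound 3

A few compounds are considered here, and "the series" means these few. Any claim that something is new, unique, unknown or untested is made for them only; others in the source may bear on it.

Of the compounds shown here, three sharing a core have been tested in an ADME assay on HPLF cells (Homo sapiens) for cytotoxicity, with a stated time of 24 h; a lower number here means that less compound is tolerated, a higher number that more compound is tolerated: compound 1 `Cc1ccc(/C=C2\CCC/C(=C\c3ccccc3[N+](=O)[O-])C2=O)cc1`, compound 2 `COc1cc(/C=C2\CCC/C(=C\c3ccccc3[N+](=O)[O-])C2=O)cc(OC)c1OC` and compound 3 `O=C1/C(=C/c2ccccc2)CCC/C1=C\c1cccc([N+](=O)[O-])c1`. Compound 1 gives > 400000 nM, which is a limit of the assay and not a number. Compound 2 gives 79000 nM. Compound 3 gives 18000 nM, the lower of the two actual numbers, and its gap to compound 2 lies beyond the scatter.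

The next compound, compound 4 `COc1ccc(/C=C2\CCC/C(=C\c3cccc([N+](=O)[O-])c3)C2=O)cc1`, differs from compound 3 by methoxy in place of hydrogen on an aromatic carbon, para to a large group (methoxy in place of hydrogen on an aromatic carbon). For the measured compounds named here, no measured pair isolates this change, so any forecast in this assay remains loose. A modest rise is expected, which may only just clear the scatter. This expectation rests on compound 2, which also carries methoxy groups, at 79000 nM. That amounts to an estimated step of a 1.8-fold higher number from compound 3 to compound 4 (0.25 log units; within the scatter). For compound 4 the expected value is 32000 nM, within an estimated range of 11000 nM to 120000 nM.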

Compound 4, half-maximal cytotoxic concentration: 354000 nM
Estimate against measurement, compound 4: 11-fold (1.04 log units) below, outside the stated range (above it).
By their numbers in this assay, from the lowest: compound 3; then compound 2; then compound 4. At a limit, above all of these: compound 1.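

In this assay, for the compounds shown here, the change from phenyl to 4-methoxyphenyl comes to a 20-fold higher number from compound 3 to compound 4 (1.29 log units; beyond the scatter), the first step in this set that isolates a single change. It shows that methoxy in place of hydrogen, on an aromatic carbon para to a large group, goes with much more compound being tolerated, a large step that lies well beyond the scatter. The number for compound 4 is still an actual value, but the assay has an upper end that bounds how far such a rise can be read: the limit of > 400000 nM in this assay, at which 1 of the 4 values shown sits.

On these data alone, whether a hydroxyl, an amine or a longer ether chain at this position would give a similar rise remains open. Also open, as far as these compounds go, is whether the same change would carry over to compounds with the nitro group placed as in compound 2.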